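Adding ethyl to the hydroxymethyl of compound 2

The source may hold more compounds than are shown below. What is called first, only, known or untested is meant among the compounds shown, and "the series" means these compounds.

In a functional assay on A549 cells (Homo sapiens) for cytotoxicity, read by MTT assay, with a stated time of 72 h (on this read-out lower numbers stand for an effect already at smaller amounts and higher numbers for an effect only at larger amounts of compound), compound 1 `CCOC(=O)c1c(C)coc1-c1ccc2c(CC)cccc2c1OC` gives 3.8 ug/mL and compound 2 `CCc1cccc2c(OC)c(-c3occ(C)c3CO)ccc12` gives 9.6 ug/mL, the higher of the two numbers. Among the compounds with values here, the one measured step is a 2.5-fold higher number from compound 1 to compound 2 (0.40 log units; beyond the scatter), a modest change that came with hydroxymethyl in place of ethoxycarbonyl on an aromatic carbon.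

Compound 3 `CCOCc1c(C)coc1-c1ccc2c(CC)cccc2c1OC` changes compound 2 at that same group, from hydroxymethyl to ethoxymethyl, with ethyl in place of hydrogen on an oxygen on a saturated carbon. Within the data shown here, no measured step covers this change directly, so the step from compound 1 is the only guide. Like compound 1, compound 3 carries an ethyl group, so a partial return toward the lower number in this assay is expected, but no more than a step of similar size. The expected step is small and toward a lower number: a 1.7-fold lower number from compound 2 to compound 3 (0.24 log units; within the scatter). For compound 3 the estimate is 5.5 ug/mL, with an expected range of 2.5 ug/mL to 12 ug/mL.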

Compound 3, concentration for half-maximal effect: > 10 ug/mL
Compound 3: a limit, no number; the forecaster's own chance of this, stated with the estimate: 3%; at least 1.8-fold (0.25 log units) between middle value and limit.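

In this assay compound 3 gives > 10 ug/mL, which is a limit and not a number: the limit of > 10 ug/mL in this assay, at which 1 of the 3 values shown sits. Ethyl in place of hydrogen on the oxygen gives an at least 1.0-fold higher number from compound 2 to compound 3 (0.01 log units; that floor lies within the scatter), so this floor does not show that the change from hydroxymethyl to ethoxymethyl moves the read-out in either direction. The firmer result comes from the other comparison, ethoxymethyl in place of ethoxycarbonyl, which gives an at least 2.6-fold higher number from compound 1 to compound 3 (0.42 log units; beyond the scatter), so at this position the ethyl group did not by itself bring back the lower number of compound 1.

The compounds shown leave open how far beyond its limit compound 3 lies. They also leave open how a carboxylic acid, an amide or a methoxymethyl group at this position would read.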